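The compounds below may be only part of what the source reports. "The series", "measured", "known", "first", "only" and "open" are said of these compounds alone.

Measured in a physicochemical assay for lipophilicity; a higher number here means a more lipophilic compound, a lower number a more polar compound:
Compound 1 `C=C(c1cccc2ccccc12)C1CCC2(CC1)COC(Nc1ccc(OC)cc1)OO2`: 5.46
Compound 2 `C=C(c1cccc2ccccc12)C1CCC2(CC1)COC(Nc1cccc(C(F)(F)F)c1)OO2`: 6.51
Compound 3 `C=C(c1ccc2ccccc2c1)C1CCC2(CC1)COC(Nc1ccccc1)OO2`: 5.59

Compound 2 stands highest of these three, and both compound 1 and compound 3 lie below it by more than the scatter of repeated measurements. Within the data shown here, only one measured step changes a single place, a number 1.05 log units higher from compound 1 to compound 2 (beyond the scatter). It is large, and it puts 3-(trifluoromethyl)phenyl in place of 4-methoxyphenyl on an amine nitrogen.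

Compound 4 `C=C(c1ccc2ccccc2c1)C1CCC2(CC1)COC(Nc1cccc(C(F)(F)F)c1)OO2` keeps the 3-(trifluoromethyl)phenyl group of compound 2 and changes another place: naphthalen-2-yl in place of naphthalen-1-yl on a double-bonded chain carbon bound to a saturated ring carbon. In words, this is naphthalen-2-yl in place of naphthalen-1-yl on a double-bonded chain carbon bound to a saturated ring carbon. The two compounds have the same atoms, joined differently.

Among the measured compounds shown here, no measured step tests this swap on its own, so the large step above does not carry over to it. For the measured compounds named here, compound 3 also bears naphthalen-2-yl, but no measured step links it to compound 2 through that change alone. With so little to go on, and the atoms unchanged, the estimated step is a number 0.01 log units lower from compound 2 to compound 4 (within the scatter), which would be none beyond the scatter. For compound 4 the expected value is 6.5, with an expected range from 6.1 to 6.9.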

Compound 4, partition coefficient: 6.51
For compound 4 the middle estimate is 0.01 log units below the measured one, within the range that was stated.
By their numbers in this assay, from the lowest: compounds 1 and 3 (each within the scatter of the next); then compounds 2 and 4 (each within the scatter of the next).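

In this assay, naphthalen-2-yl in place of naphthalen-1-yl on a double-bonded chain carbon bound to a saturated ring carbon gives no change at the digits printed from compound 2 to compound 4 (within the scatter), so with the 3-(trifluoromethyl)phenyl group in place, rejoining the same atoms at this position leaves the reading unmoved. The other new step isolates a single addition with naphthalen-2-yl held constant: trifluoromethyl in place of hydrogen on an aromatic carbon gives a number 0.92 log units higher from compound 3 to compound 4 (beyond the scatter), which the earlier step from compound 1 to compound 2 could not show, since that step also removed the methoxy group. No supporting evidence is available to explain either result.

The naphthalene swap has been read only with the 3-(trifluoromethyl)phenyl group, so the compounds shown leave open whether it would be as flat with the plain phenyl of compound 3 or the 4-methoxyphenyl of compound 1. They also leave open how far the reading would move with a carboxylic acid or an amine in place of the trifluoromethyl group.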